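A Larger Aryl Group on the Shared Core

A few compounds are considered here, and "the series" means these few. Any claim that something is new, unique, unknown or untested is made for them only; others in the source may bear on it.

Compound 3 `N#CC1=C(N)N(c2ccc(S(N)(=O)=O)cc2)C2=C(C(=O)CCC2)C1c1cccc([N+](=O)[O-])c1` gives, in a functional assay on Ehrlich cells (Mus musculus) for antiproliferative activity, read by trypan blue exclusion, with a stated time of 2 h (a higher number here means a weaker inhibitor, a lower number a stronger inhibitor), 25 ug/mL. It stands level with compound 2 `COc1ccc(C2C(C#N)=C(N)N(c3ccc(S(N)(=O)=O)cc3)C3=C2C(=O)CCC3)cc1`, which in this assay gives 25 ug/mL, and the two share the lowest number among the three measured compounds. Compound 1 `Cc1ccc(C2C(C#N)=C(N)N(c3ccc(S(N)(=O)=O)cc3)C3=C2C(=O)CCC3)cc1` gives 50 ug/mL in this assay; the step of a 2.0-fold lower number from compound 1 to compound 3 (0.30 log units; within the scatter) and the step of a 2.0-fold lower number from compound 1 to compound 2 (0.30 log units; within the scatter) both lie within the scatter, as does the step of no change at the digits printed from compound 2 to compound 3 (within the scatter). Compound 4 `N#CC1=C(N)N(c2ccc(S(N)(=O)=O)cc2)C2=C(C(=O)CCC2)C1c1c(O)ccc2ccccc12` has not yet been measured. It differs from compound 3 in one place: 2-hydroxynaphthalen-1-yl in place of 3-nitrophenyl on a saturated ring carbon. Two of the measured steps change the aryl group on that same saturated ring carbon, namely a 2.0-fold lower number from compound 1 to compound 3 (0.30 log units; within the scatter) and no change at the digits printed from compound 2 to compound 3 (within the scatter), and neither moved the number beyond the scatter. For the measured compounds named here, on this basis no step beyond the scatter is expected for compound 4 in this assay, although the group that enters has no counterpart among the measured compounds, so the range is kept wide. The step expected from this change is no change at the digits printed from compound 3 to compound 4 (within the scatter). Compound 4 is estimated at 25 ug/mL, with a range from 10 ug/mL to 60 ug/mL.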

Compound 4, half-maximal inhibitory concentration: > 100 ug/mL
Compound 4 ended at the assay's limit; the forecaster's own chance of this, stated with the estimate: 5%; middle value at least 4.0-fold (0.60 log units) away from the limit.
By their numbers in this assay, from the lowest: compounds 2, 3 and 1 (each within the scatter of the next). At a limit, above all of these: compound 4.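

For the compounds shown here, the aryl group on this saturated ring carbon is not interchangeable after all: the 2-hydroxynaphthalen-1-yl group gives the first changes at this position that lie beyond the scatter, an at least 4.0-fold higher number from compound 3 to compound 4 (0.60 log units; beyond the scatter) and an at least 4.0-fold higher number from compound 2 to compound 4 (0.60 log units; beyond the scatter), whereas the 4-methylphenyl, 4-methoxyphenyl and 3-nitrophenyl groups remain within the scatter of one another. The comparison with the 4-methylphenyl group is less decisive, as an at least 2.0-fold higher number from compound 1 to compound 4 (0.30 log units; that floor lies within the scatter) has a floor that does not clear the scatter, so compound 1 and compound 4 are not firmly separated. In this assay, compound 4 gives > 100 ug/mL, which is a limit of the assay and not a number: the limit of > 100 ug/mL in this assay, at which 1 of the 4 values shown sits.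

The entering group brings both a second aromatic ring and a hydroxy group, and the compounds shown do not tell which of these goes with the higher number. As far as these compounds go, it remains open how a plain naphthalen-1-yl group or a 2-hydroxyphenyl group on the same carbon would read, and either would help to separate the two features.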